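A few compounds are considered here, and "the series" means these few. Any claim that something is new, unique, unknown or untested is made for them only; others in the source may bear on it.

In a physicochemical assay for lipophilicity, measured as octanol-water partition (a lower number here means a more polar compound, a higher number a more lipophilic compound), compound 2 `CC(C)[C@@H]1CC[C@@H](C)C[C@H]1OC(=O)c1ccc(Cl)cc1` gives 5.34 and stands within the scatter of compound 3 `CC(C)[C@@H]1CC[C@@H](C)C[C@H]1OC(=O)/C=C/c1ccc([N+](=O)[O-])cc1` with 5.18 in the same read-out. Compound 1 `CC(C)[C@@H]1CC[C@@H](C)C[C@H]1OC(=O)c1ccc(Cl)cc1Cl` gives 5.86 and lies beyond the scatter on the higher side of compound 2.

The change leading to compound 4 `CC(C)[C@@H]1CC[C@@H](C)C[C@H]1OC(=O)c1ccccc1` is hydrogen in place of chloro on an aromatic carbon and amounts to hydrogen in place of chloro on an aromatic carbon, para to a large group.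

One measured step is of the same kind, also hydrogen in place of chloro on an aromatic carbon. It is a number 0.52 log units lower from compound 1 to compound 2 (beyond the scatter) and counts as modest. Among the compounds with values here, no measured step connects compound 3 to the others, so compound 3 offers no guide. Within the data shown here, a single step is thin support, and no measurement yet shows the size of this exchange at the carbon concerned.

Among the measured compounds shown here, with a number 0.52 log units lower from compound 1 to compound 2 (beyond the scatter) as the only guide, a step of similar modest size is expected in this assay toward a lower number. The expected move is a number 0.49 log units lower from compound 2 to compound 4 (beyond the scatter) on this reasoning. For compound 4 the estimate is 4.85 with an expected range from 4.5 to 5.2 for repeated measurements.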

Compound 4, partition coefficient: 4.82
For compound 4 the middle estimate is 0.03 log units above the measured one, and the stated range covers the measured number.
By their numbers in this assay, from the lowest: compound 4; then compounds 3 and 2 (each within the scatter of the next); then compound 1.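

In this assay, the chloro para to a large group now has a measured step of its own: hydrogen in its place gives a number 0.52 log units lower from compound 2 to compound 4 (beyond the scatter). This step has the same printed size as a number 0.52 log units lower from compound 1 to compound 2 (beyond the scatter), which removes the other chloro of compound 1, so the two exchanges of chloro for hydrogen, made at two different carbons of the aromatic ring, come out alike across compound 1, compound 2 and compound 4, and none of these three goes against that reading. Nothing measured here explains why the two steps match in size.

As far as these compounds go, the series still holds only chloro and hydrogen at this carbon among the benzoates, so it remains open whether a fluoro, a methoxy, an amine or a carboxylic acid there would move the number by a similar step or by a very different one. Compound 3 also remains unconnected to the other compounds by any single change, and a benzoate carrying a nitro group at this same carbon would be needed to tie it to them.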